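Methylsulfonyl for isobutoxy: cytotoxicity expected to remain unmeasurable

A few compounds are considered here, and "the series" means these few. Any claim that something is new, unique, unknown or untested is made for them only; others in the source may bear on it.

compound 1 `CCOC(=O)c1c(-c2cccc(OCC(C)C)c2)[nH]c2cc(OC)ccc2c1=O`: > 22000 nM
compound 2 `CCOC(=O)c1c(-c2cccc(C(F)(F)F)c2)[nH]c2cc(OC)ccc2c1=O`: > 22000 nM

In an ADME assay on HEK293 cells (Homo sapiens) for cytotoxicity, read by luminescence, with a stated time of 72 h (on this read-out higher numbers stand for an effect only at larger amounts of compound and lower numbers for an effect already at smaller amounts), compound 1 gives only > 22000 nM, which is a limit of the assay and not a number. Compound 2 likewise stops at > 22000 nM, again a limit. Among the measured compounds shown here, compound 1 therefore stands nowhere on a scale of numbers: both values shown sit at the same limit (the limit of > 22000 nM in this assay, at which 2 of the 2 values shown sit), and the single measured step, a step that the two limits leave unreadable from compound 1 to compound 2, cannot be read in either size or direction.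

Compound 3 `CCOC(=O)c1c(-c2cccc(S(C)(=O)=O)c2)[nH]c2cc(OC)ccc2c1=O` differs from compound 1 in one place: methylsulfonyl in place of isobutoxy on an aromatic carbon. For the measured compounds named here, the only measured step, the one exchanging isobutoxy for trifluoromethyl, bears on this change in so far as it too replaces the isobutoxy. Both ends of that step are limits, and it gives no size. Nothing in the data points toward an effect at smaller amounts for compound 3.

Compound 3 is thus expected to give 30000 nM in this assay, within 15000 nM to 60000 nM, most probably again as a limit. The expected step that the limit leaves unreadable from compound 1 to compound 3 is no step beyond the scatter.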

Compound 3, half-maximal effective concentration: > 22000 nM
Compound 3: only a limit was reported; the forecaster's own chance of this, stated with the estimate: 85%; the middle value is on the limit's open side.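

In this assay compound 3 gives > 22000 nM, again a limit and not a number. Neither the step from compound 1 to compound 3 nor the step from compound 2 to compound 3 can be read in size or direction: the limit of > 22000 nM in this assay, at which 3 of the 3 values shown sit.

The compounds shown leave open whether any group at this place would bring an effect at smaller amounts.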